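Methyl for fluoro on the aromatic ring: expected tolerability

This account rests on a few compounds, and the source may have more. Where it says the series, first, only, none or still open, it means among the compounds named here.

Compound 2 `CCCC[C@H](CCn1cncn1)c1ccc(F)cc1` gives 35.2 ug/mL in an ADME assay on RD cells (Homo sapiens) for cytotoxicity, read by MTT assay, with a stated time of 3 days; a lower number here means that less compound is tolerated, a higher number that more compound is tolerated. Among the two numbers measured, compound 2 stands lowest; the nearest is compound 1 `CCCC[C@H](CCn1cncn1)c1ccccc1`, which in this assay gives 48.3 ug/mL, the step of a 1.4-fold lower number from compound 1 to compound 2 (0.14 log units; within the scatter) lying within the scatter. Compound 3 `CCCC[C@H](CCn1cncn1)c1ccc(C)cc1` differs from compound 2 as follows: methyl in place of fluoro on an aromatic carbon. Within the data shown here, no measured step bears directly on exchanging methyl for fluoro at that aromatic carbon; the only step at that carbon, a 1.4-fold lower number from compound 1 to compound 2 (0.14 log units; within the scatter), was within the scatter, so no step beyond the scatter is expected here. Compound 3 is therefore estimated at 40 ug/mL (20 ug/mL to 80 ug/mL), a step of a 1.1-fold higher number from compound 2 to compound 3 (0.06 log units; within the scatter).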

Compound 3, half-maximal cytotoxic concentration: 26.5 ug/mL
For compound 3 the middle estimate is 1.5-fold (0.18 log units) above the measured one, and the stated range covers the measured number.
By their numbers in this assay, from the lowest: compounds 3, 2 and 1 (each within the scatter of the next).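

On the aromatic carbon para to a large group, hydrogen, fluoro and methyl now read alike in this assay: a 1.3-fold lower number from compound 2 to compound 3 (0.12 log units; within the scatter) and a 1.8-fold lower number from compound 1 to compound 3 (0.26 log units; within the scatter) both lie within the scatter. Neither exchange of one heavy atom at this position therefore gives a step beyond the scatter, with methyl adding to what fluoro showed. No available evidence accounts for these numbers.

On these data alone, whether the position stays this flat with an amine, a carboxylic acid or trifluoromethyl remains open. So does the effect of a longer chain on the shared core.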